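Replacing Pyridin-4-yl in Compound 3

This account rests on a few compounds, and the source may have more. Where it says the series, first, only, none or still open, it means among the compounds named here.

Values so far from a functional assay on HOS-TE85 cells (Homo sapiens) for inhibition, read by CCK-8 assay, with a stated time of 72 h (on this read-out higher numbers stand for weaker inhibition and lower numbers for stronger inhibition), are these:
Compound 1 `O=C(NCCCCn1cccn1)c1cccc(C2SCC(=O)N2c2ccccn2)c1` gives 60.3 nM
Compound 2 `O=C(NCCCCn1cccn1)c1cccc(C2SCC(=O)N2c2cc(Cl)ccn2)c1` gives 36.4 nM
Compound 3 `O=C(NCCCCn1cccn1)c1cccc(C2SCC(=O)N2c2ccncc2)c1` gives > 1000 nM

Going by these compounds, the entry for compound 3 is a limit of the assay and not a number, so its true value is unknown.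

Compound 4 `O=C(NCCCCn1cccn1)c1cccc(C2SCC(=O)N2c2cc(F)ccn2)c1` changes one group of compound 3: 4-fluoropyridin-2-yl in place of pyridin-4-yl on an amide-type nitrogen in a ring. In words, 4-fluoropyridin-2-yl stands in place of pyridin-4-yl on an amide-type nitrogen in a ring.

For the measured compounds named here, three measured steps bear on this change. Chloro in place of hydrogen gave a 1.7-fold lower number from compound 1 to compound 2 (0.22 log units; within the scatter) and so made little difference. Pyridin-4-yl in place of the other two groups gave an at least 16-fold higher number from compound 1 to compound 3 (1.21 log units; beyond the scatter) and an at least 27-fold higher number from compound 2 to compound 3 (1.43 log units; beyond the scatter), both large. The new group resembles the 4-chloropyridin-2-yl group of compound 2 at 36.4 nM, so a large move towards lower numbers is expected in this assay. The expected change is an at least 22-fold lower number from compound 3 to compound 4 (1.34 log units; beyond the scatter). The estimate for compound 4 is 45 nM with an expected range from 15 nM to 150 nM.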

Compound 4, half-maximal inhibitory concentration: 33.2 nM
For compound 4 the middle estimate is 1.4-fold (0.13 log units) above the measured one; the range from low to high includes it.
By their numbers in this assay, from the lowest: compounds 4, 2 and 1 (each within the scatter of the next). At a limit, above all of these: compound 3.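

In this assay, putting 4-fluoropyridin-2-yl in place of pyridin-4-yl gives an at least 30-fold lower number from compound 3 to compound 4 (1.47 log units; beyond the scatter), so the large step seen earlier with the hydrogen and chloro versions now appears with a third pyridin-2-yl group. Fluoro itself changes little, with a 1.1-fold lower number from compound 2 to compound 4 (0.04 log units; within the scatter) and a 1.8-fold lower number from compound 1 to compound 4 (0.26 log units; within the scatter), so hydrogen, chloro and fluoro on this ring cannot be told apart in this read-out. The entry for compound 3 is a limit and not a number, so the size of its step has no upper end: the limit of > 1000 nM in this assay, at which 1 of the 4 values shown sits.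

Still open, going by these compounds, is whether a plain phenyl ring on the same amide-type nitrogen would stay with compounds 1, 2 and 4 or fall with compound 3. Also open, on these data alone, is whether a methoxy group or an amine on the pyridin-2-yl ring would leave the number within the scatter of these three.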